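Methyl for Chloro on the Aryl Ring of Compound 3

This account rests on a few compounds, and the source may have more. Where it says the series, first, only, none or still open, it means among the compounds named here.

In a functional assay on PC-3 cells (Homo sapiens) for inhibition, read by MTT assay, with a stated time of 48 h (a higher number here means a weaker inhibitor, a lower number a stronger inhibitor), compound 1 `COc1cc(N(Cc2ccc(Br)cc2)S(=O)(=O)c2ccc(C)cc2)cc(OC)c1OC` gives 4680 nM, compound 2 `COc1cc(N(Cc2nc3ccccc3[nH]2)S(=O)(=O)c2ccccc2Cl)cc(OC)c1OC` gives 34500 nM, and compound 3 `Cc1ccc(S(=O)(=O)N(Cc2nc3ccccc3[nH]2)c2ccc(Cl)cc2)cc1` gives 42200 nM. Compound 3 has the highest of the three numbers; compound 2 lies within the scatter of it, while compound 1 stands beyond the scatter with a lower number. Compound 4 `Cc1ccc(N(Cc2nc3ccccc3[nH]2)S(=O)(=O)c2ccc(C)cc2)cc1` differs from compound 3 by methyl in place of chloro on an aromatic carbon, which, cut one bond further out, reads as 4-chlorophenyl to 4-methylphenyl. Among the compounds with values here, no measured pair shows this exchange, so there is no step to lean on. The exchange is expected to move this assay little, with a step of a 1.1-fold lower number from compound 3 to compound 4 (0.02 log units; within the scatter) of no size beyond the scatter. Compound 4 is therefore estimated at 40000 nM, within 15000 nM to 110000 nM.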

Compound 4, half-maximal inhibitory concentration: 48900 nM
The estimate for compound 4 lay 1.2-fold (0.09 log units) below the measured number; low and high end bracket the measured number.
By their numbers in this assay, from the lowest: compound 1; then compounds 2, 3 and 4 (each within the scatter of the next).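

In this assay, methyl in place of chloro on this aromatic carbon, para to a large group, gives a 1.2-fold higher number from compound 3 to compound 4 (0.06 log units; within the scatter), so the two compounds cannot be told apart at this position. Within the data shown here, this is the first pair here that differs in one place, and it shows that this exchange alone leaves the number within the scatter. No measurement bearing on why accompanies this result. The compounds shown leave open whether an amine or a carboxylic acid at this position would give a number beyond the scatter. They also leave open whether the same exchange would read alike on the core of compound 1.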